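The source may report more compounds than this note shows. Statements on the series, on what has been measured and on what is new or still open speak of the compounds shown alone.

Measured so far in an assay on isolated protein for inhibition of sphingosine kinase 1 (Homo sapiens), read by mobility shift assay; on this read-out lower numbers stand for stronger inhibition and higher numbers for weaker inhibition:
compound 1, `CCCCCCCCc1ccc(NC(=O)[C@H](CO)NC)cc1`, gives 2800 nM;
compound 2, `CCCCCCCCc1ccc(CNC(=O)C(N)CO)cc1`, gives only a limit of the assay, > 10000 nM;
compound 3, `CCCCCCCCc1ccc(NC[C@@H](N)CO)cc1`, gives 5000 nM.

Compound 1 stands at the lowest of the two numbers in this assay. Its nearest neighbour is compound 3, and the step of a 1.8-fold higher number from compound 1 to compound 3 (0.25 log units; within the scatter) lies within the scatter, so the two cannot be ordered. Compound 2 sits at the limit of > 10000 nM in this assay, at which 1 of the 3 values shown sits, and gives no number to compare.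

The new compound is compound 4, `CCCCCCCCc1ccc(NC(=O)[C@H]2NC[C@@H](O)[C@@H]2O)cc1`. It differs from compound 1 in one place: 3,4-dihydroxypyrrolidin-2-yl in place of 2-hydroxy-1-(methylamino)ethyl on a carbonyl carbon. Among the compounds with values here, the only measured step, from compound 1 to compound 3, also reworked the group carried on the aromatic nitrogen and stayed within the scatter; no measured step tests a dihydroxypyrrolidine against an open-chain hydroxyamine on this core. Within the data shown here, with that single step as the only guide, the expectation is no step beyond the scatter, in either direction, with wide uncertainty. Compound 4 is therefore expected to give about 3500 nM in this assay, between 1000 nM and 12000 nM. The expected step of a 1.3-fold higher number from compound 1 to compound 4 (0.10 log units; within the scatter) is thus estimated to stay within the scatter.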

Compound 4, half-maximal inhibitory concentration: 8300 nM
Compound 4: the middle estimate sits 2.4-fold (0.38 log units) below what was measured; low and high end bracket the measured number.
By their numbers in this assay, from the lowest: compounds 1, 3 and 4 (each within the scatter of the next, the first and the last beyond it). At a limit, above all of these: compound 2.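

In this assay, the step of a 1.8-fold higher number from compound 1 to compound 3 (0.25 log units; within the scatter) had left open whether reworking the polar end of the shared core changes the reading at all, whereas the step of a 3.0-fold higher number from compound 1 to compound 4 (0.47 log units; beyond the scatter) lies beyond the scatter, though it is modest. On the carbonyl carbon, then, the exchange of the open-chain 2-hydroxy-1-(methylamino)ethyl for the ring-bearing 3,4-dihydroxypyrrolidin-2-yl weakens inhibition, but compound 4 still gives a measured number rather than a limit of the assay. Nothing shown here accounts for this step.

The change brings in a ring, a further hydroxyl and further defined stereocentres all at once, and the compounds shown do not separate these, so it remains open whether a plain pyrrolidin-2-yl or a 3-hydroxypyrrolidin-2-yl group on the same carbonyl carbon would stand closer to compound 1 or to compound 4. From the compounds shown here alone, it is also open whether a simple open-chain 2-hydroxy-1-aminoethyl group, with a primary amine in place of the methylamino group, would read differently from compound 1 on this core.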